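The compounds below may be only part of what the source reports. "The series", "measured", "known", "first", "only" and "open" are said of these compounds alone.

Three compounds were measured in a functional assay on cells (Homo sapiens) for cytotoxicity, read by sulforhodamine B assay, with a stated time of 2 days; on this read-out lower numbers stand for stronger inhibition and higher numbers for weaker inhibition:

compound 1 `OCc1cc(N2CCCC2)ccc1-c1nc2c(s1)C(O)CCC2`: 44 nM
compound 2 `CN(C)c1ccc(-c2nc3c(s2)C(O)CNC3)c(CO)c1`: 100 nM
compound 3 `OCc1cc(N2CCCC2)ccc1-c1nc2c(s1)C(O)CNC2`: 60 nM

Compound 3 and compound 2 share a core and differ in one place only: dimethylamino in place of pyrrolidin-1-yl on an aromatic carbon. That change gave a 1.7-fold higher number from compound 3 to compound 2 (0.22 log units; within the scatter), a step small enough to count as no real difference. Compound 1 has a different core from compound 3, and the difference between the two cores is not broken down here; what is shown is that compound 1 gives the lowest of the three numbers.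

Compound 4 `CN(C)c1ccc(-c2nc3c(s2)C(O)CCC3)c(CO)c1` is not yet measured. It stands to compound 1 as compound 2 stands to compound 3: dimethylamino in place of pyrrolidin-1-yl on an aromatic carbon, the same change at the same place. The step from compound 1 to compound 4 is expected to be a 1.7-fold higher number from compound 1 to compound 4 (0.23 log units; within the scatter), resting on the earlier 1.7-fold higher number from compound 3 to compound 2 (0.22 log units; within the scatter). Compound 4 is therefore estimated at 75 nM, most likely between 40 nM and 140 nM.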

Compound 4, half-maximal inhibitory concentration: 60 nM
Compound 4: the middle estimate sits 1.3-fold (0.10 log units) above what was measured; the range from low to high includes it.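

In this assay, putting dimethylamino in place of pyrrolidin-1-yl again made no real difference, giving a 1.4-fold higher number from compound 1 to compound 4 (0.13 log units; within the scatter). Set beside the earlier step, the change behaves alike on both cores: the same change on two cores in this assay, a 1.7-fold higher number (0.22 log units; within the scatter) from compound 3 to compound 2 and a 1.4-fold higher number (0.13 log units; within the scatter) from compound 1 to compound 4, 1.2-fold (0.09 log units) apart, within the scatter of two such steps. So, between these two cores, the swap carries over and leaves the number within the scatter, but neither step shows that it moves the number in any real way, and two cores cannot show that the same would hold across the whole series.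

The compounds shown leave open what a morpholine ring or a carboxylic acid would do at that place on the aromatic ring. They also leave open whether the swap would behave the same on a third core.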